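A few compounds are considered here, and "the series" means these few. Any claim that something is new, unique, unknown or untested is made for them only; others in the source may bear on it.

Three chlorophenyl-bearing analogues sharing one core were examined in a functional assay on HCT-116 cells (Homo sapiens) for cytotoxicity, read by a luciferase reporter and CellTiter-Glo, with a stated time of 72 h; on this read-out higher numbers stand for weaker inhibition and lower numbers for stronger inhibition. In this assay, among the measured compounds shown here, compound 1 (`COc1ccc(C2=NN(c3ccccc3Cl)C(c3cccc(Cl)c3)C2)cc1`) gives 1500 nM, the only number the series has so far. Compound 2 (`COc1ccc(C2=NN(c3cccc(Cl)c3)C(c3cccc(Cl)c3)C2)cc1`) has no single number to stand on, its entry reading "not determined" (no result reported). Compound 3 (`COc1ccc(C2=NN(c3cccc(Cl)c3)C(c3ccccc3Cl)C2)cc1`) fares no better, with the entry "not determined" (no result reported). Compound 4 (`COc1ccccc1C1=NN(c2cccc(Cl)c2)C(c2cccc(Cl)c2)C1`) has yet to be measured and differs from compound 2 in one place: 2-methoxyphenyl in place of 4-methoxyphenyl on a carbon with a double bond to nitrogen. This puts 2-methoxyphenyl in place of 4-methoxyphenyl on a carbon with a double bond to nitrogen, with the same atoms joined differently. For the measured compounds named here, no step between measured compounds exists to show what such a change does in this assay, and compound 2 offers no value to start from. The expectation therefore leans on compound 1 at 1500 nM, and no shift beyond the usual scatter is expected, in either direction. For compound 4 the estimated value is 2000 nM, with an expected range from 500 nM to 8000 nM.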

Compound 4, half-maximal inhibitory concentration: 1600 nM
Estimate against measurement, compound 4: 1.3-fold (0.10 log units) above; the measured number falls inside the stated range.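

Among the compounds shown here, compound 2 has no single number in this assay, and no step to compound 4, at 1600 nM, can be read. Going by these compounds, what 2-methoxyphenyl in place of 4-methoxyphenyl does to this read-out stays open. No evidence at hand bears on this result.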